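A few compounds are considered here, and "the series" means these few. Any claim that something is new, unique, unknown or untested is made for them only; others in the source may bear on it.

In a functional assay on A2780 cells (Homo sapiens) for antiproliferative activity, read by MTT assay, with a stated time of 72 h (on this read-out lower numbers stand for stronger inhibition and higher numbers for weaker inhibition), compound 3 `CCCCCCCNC(=N)NC(=N)Nc1ccc(F)c(F)c1` gives 1500 nM, the lowest of the three numbers; compound 1 `N=C(NC(=N)NC1CCCC1)Nc1ccc(C(F)(F)F)cc1` gives 2500 nM, which lies within the scatter of it, while compound 2 `CCN(C)C(=N)NC(=N)Nc1ccc(C(F)(F)F)cc1` gives 5100 nM, beyond the scatter. Compound 4 `CC(C)NC(=N)NC(=N)Nc1ccc(F)c(F)c1` differs from compound 3 in one place: isopropyl in place of heptyl on an amine nitrogen. Among the compounds with values here, the one measured step that touches the same kind of position is a 2.0-fold higher number from compound 1 to compound 2 (0.31 log units; beyond the scatter), a modest rise when one group on the nitrogen gave way to another. The exchange of heptyl for isopropyl is a change of the same kind, so a modest rise, if any, is expected rather than a fall. Compound 4 is therefore expected to give 3000 nM, with a range from 1200 nM to 7500 nM, an expected step of a 2.0-fold higher number from compound 3 to compound 4 (0.30 log units; within the scatter).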

Compound 4, half-maximal inhibitory concentration: 26000 nM
Estimate against measurement, compound 4: 8.7-fold (0.94 log units) below, outside the stated range (above it).
By their numbers in this assay, from the lowest: compounds 3 and 1 (each within the scatter of the next); then compound 2; then compound 4.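

In this assay the exchange of heptyl for isopropyl on an amine nitrogen gives a 17-fold higher number from compound 3 to compound 4 (1.24 log units; beyond the scatter) and this large step far exceeds the modest 2.0-fold higher number from compound 1 to compound 2 (0.31 log units; beyond the scatter) seen in the earlier pair. Within the data shown here, the group on this nitrogen can therefore move the number much further than the earlier compounds showed, and here the shorter group goes with the higher number. Nothing available explains the size of this step. The compounds shown leave open whether a butyl chain would give a number nearer that of compound 3 or that of compound 4. They also leave open whether an octyl chain would extend the trend or reverse it.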